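The source may report more compounds than this note shows. Statements on the series, on what has been measured and on what is new or still open speak of the compounds shown alone.

Compound 1 `COc1ccc(OC)c(/C=N/NC(=O)Nc2ccc(Oc3ccnc(-c4nncn4CCN(C)C)c3)c(F)c2)c1` carries the shared core with a 2,5-dimethoxyphenyl group on the carbon that is double-bonded to nitrogen. In an ADME assay on WI-38 cells (Homo sapiens) for cytotoxicity, read by MTT assay, with a stated time of 72 h (a higher number here means a weaker inhibitor, a lower number a stronger inhibitor), compound 1 has no single number, its entry reading "not determined" (no result reported). Compound 2 `CN(C)CCn1cnnc1-c1cc(Oc2ccc(NC(=O)N/N=C/c3cccc(Br)c3)cc2F)ccn1` gives 4230 nM in this assay, while compound 3 `CN(C)CCn1cnnc1-c1cc(Oc2ccc(NC(=O)N/N=C/c3cc(Br)c(O)c(Br)c3)cc2F)ccn1` likewise stands at "not determined" (no result reported) there. Compound 4 `Cc1cc(/C=N/NC(=O)Nc2ccc(Oc3ccnc(-c4nncn4CCN(C)C)c3)c(F)c2)cc(C)c1O` is the one still to be measured; it differs from compound 1 by 4-hydroxy-3,5-dimethylphenyl in place of 2,5-dimethoxyphenyl on a carbon with a double bond to nitrogen. Going by the values given here, since no measured step is on record for this change, only a modest shift in this assay is expected, in no clear direction and possibly within the ordinary scatter. On that basis compound 4 is estimated at 4000 nM, with a range from 1500 nM to 12000 nM.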

Compound 4, half-maximal inhibitory concentration: 3610 nM
For compound 4 the middle estimate is 1.1-fold (0.04 log units) above the measured one; low and high end bracket the measured number.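

Placing 4-hydroxy-3,5-dimethylphenyl in place of 3-bromophenyl on a carbon with a double bond to nitrogen gives, in this assay, a 1.2-fold lower number from compound 2 to compound 4 (0.07 log units; within the scatter). The two groups are therefore not told apart at this position, although one carries a bromine and the other a hydroxyl with two methyl groups. The step from compound 1 to compound 4 cannot be read, as compound 1 has no single number. No measurement on hand explains the result. As far as these compounds go, whether an amine or a carboxylic acid on this aromatic ring would separate from these values remains open.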